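Furfurylamino quinazolines: diethylaminoethyl replacing methoxyphenyl

The compounds below may be only part of what the source reports. "The series", "measured", "known", "first", "only" and "open" are said of these compounds alone.

Measured compounds:
- compound 1, `CCN(CC)CCNc1nc(NCc2ccco2)c2ccccc2n1`: 75.1%
- compound 2, `COc1ccc(Nc2nc(NCc3ccco3)c3cc(F)ccc3n2)cc1`: 86.2%
- compound 3, `CCCCCNc1nc(NCc2ccco2)c2ccccc2n1`: "not determined" (no result reported)

In a functional assay on HT-29 cells (Homo sapiens) for cytotoxicity, read by MTT assay, with a stated time of 2 days, tested at 10 uM (a higher number here means more inhibition at the concentration tested (going by the name of the read-out), a lower number less inhibition), compound 2 gives 86.2% and stands highest of the two numbers recorded; its nearest neighbour is compound 1, which gives 75.1% in this assay, a gap beyond the scatter. Compound 3 carries no number in this assay.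

Compound 4, `CCN(CC)CCNc1nc(NCc2ccco2)c2cc(F)ccc2n1`, is not yet measured. It differs from compound 2 by one change: 2-(diethylamino)ethyl in place of 4-methoxyphenyl on a nitrogen on an aromatic ring. Compound 4 thus combines the chain of compound 1 with the core of compound 2.

Among the measured compounds shown here, no step between measured compounds is known, so the size of the step from compound 2 to compound 4 rests on what compound 1 and compound 2 show. Compound 1, carrying the same chain, gives the lower number in this assay, so a modest fall toward that value is expected. The expected step is a number 8.2 percentage points lower from compound 2 to compound 4 (within the scatter), small and close to the scatter.

For compound 4 the estimate in this assay is 78%, with a range from 62% to 90%.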

Compound 4, a percentage reported as inhibition, at one concentration (the size of the read-out at that concentration, not a potency): 27.5%
Compound 4: middle estimate off by 50.5 percentage points, on the high side; the whole stated range lies above it.
By their numbers in this assay, from the lowest: compound 4; then compound 1; then compound 2.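

In this assay, 2-(diethylamino)ethyl in place of 4-methoxyphenyl on a nitrogen on an aromatic ring is a large change on the fluoro-bearing core (a number 58.7 percentage points lower from compound 2 to compound 4 (beyond the scatter)). With the 2-(diethylamino)ethyl chain held constant, fluoro in place of hydrogen on an aromatic carbon is also a large change (a number 47.6 percentage points lower from compound 1 to compound 4 (beyond the scatter)), so compound 1 alone did not show how this chain behaves on the fluoro-bearing core, and both the chain and the fluoro site count in compound 4. Nothing on hand explains either fall.

Open, going by these compounds, is whether fluoro in place of hydrogen has a comparable effect when 4-methoxyphenyl occupies the nitrogen, a question that needs the 4-methoxyphenyl compound without fluoro. Also open, on these data alone, is whether a dimethylaminoethyl or morpholinoethyl chain on the same nitrogen, or chloro in place of fluoro, would behave like compound 4.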